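Ring contraction on the thiocarbonyl carbon: compound 2 to compound 3

This account rests on a few compounds, and the source may have more. Where it says the series, first, only, none or still open, it means among the compounds named here.

Measured so far in a functional assay on A-375 cells (Homo sapiens) for cytotoxicity, read by MTT assay, with a stated time of 72 h, tested at 1 uM; a higher number here means more inhibition of growth at the concentration tested, a lower number less inhibition of growth:
- compound 1, `Cc1ccnc(/C(N)=N/NC(=S)N2CCSCC2)c1`: compound 1 gives 47.7%
- compound 2, `Cc1cccc(/C(N)=N/NC(=S)N2CCCCC2)n1`: compound 2 gives 49.9%

Compound 2 holds the top number of the two, but its gap to compound 1 falls within the scatter of repeated measurements, so the two compounds stand level on the present data and no order between them is claimed. Going by the values given here, both share the same amidrazone-thiourea arrangement carrying a saturated amine on the thiocarbonyl carbon; the pyridine substitution pattern differs as well, so no single-point step can be drawn between them.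

Compound 3, `Cc1cccc(/C(N)=N/NC(=S)N2CCCC2)n1`, is the next compound for this assay. It differs from compound 2 in one place: pyrrolidin-1-yl in place of piperidin-1-yl on a thiocarbonyl carbon. Among the compounds with values here, no pair differing in one place has been measured, so no step size is known for a change of this kind. With both measured compounds sitting close together despite two differences, a step from compound 2 to compound 3 is expected to stay within the scatter, leaning if anything slightly downward, as a number 4.9 percentage points lower from compound 2 to compound 3 (within the scatter).

For compound 3 the estimated value is 45%, with a range from 30% to 60%.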

Compound 3, percent growth inhibition at one concentration: 13.6%
Compound 3: middle estimate off by 31.4 percentage points, on the high side, and the stated range ends above it.
By their numbers in this assay, from the lowest: compound 3; then compounds 1 and 2 (each within the scatter of the next).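

In this assay, the thiocarbonyl carbon proves to be a sensitive position: replacing piperidin-1-yl with pyrrolidin-1-yl, a six-membered non-aromatic ring with a five-membered one, gives a number 36.3 percentage points lower from compound 2 to compound 3 (beyond the scatter). The earlier compounds shown here, which differ in more than one place and stand level, gave no sign that a change this small in the saturated ring could move the number by so much. The step appears with the hydrogen-bond donor and acceptor counts and the net charge of the group unchanged, and no data at hand account for it.

One step does not show whether the number follows ring size in a regular way or whether piperidin-1-yl is simply a favourable case, and an azepan-1-yl ring or an open-chain amine such as dimethylamino on the same carbon would help separate the two readings. As far as these compounds go, it also remains open whether the same contraction carries the same penalty on the core of compound 1, where a pyrrolidin-1-yl group in place of the present ring would test how far this step applies beyond the core of compound 2.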